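The source may report more compounds than this note shows. Statements on the series, on what has been measured and on what is new or still open speak of the compounds shown alone.

Of the compounds shown here, two define the series so far in an ADME assay on microsomes from liver (Mus musculus) for metabolic stability, read by LC-MS, using NADPH, tested at 4.6 uM; on this read-out higher numbers stand for a longer-lived compound and lower numbers for a shorter-lived compound. Compound 1 `CCCCCNC(=O)n1cc(-c2ccccc2)oc1=O` gives < 0.0834 h, which is a limit of the assay. Compound 2 `COc1cc(-c2cn(C(=O)NCCCCc3ccccc3)c(=O)o2)ccc1F` gives > 1 h, which is also a limit and not a number, so compound 2 stands on a limit only. The next structure is compound 3 `O=C(NCCCCc1ccccc1)n1cc(-c2cnccn2)oc1=O`, with pyrazin-2-yl in place of 4-fluoro-3-methoxyphenyl on an aromatic carbon. The rest of the structure stays the same. Going by the values given here, no measured pair gives the size of this change, so the expectation is loose: a moderate fall in this assay, possibly not much beyond the scatter. The expected step is an at least 2.0-fold lower number from compound 2 to compound 3 (0.30 log units; that floor lies within the scatter). Compound 3 is expected at 0.5 h, with an estimated range of 0.15 h to 1.5 h.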

Compound 3, half-life: 1 h
Compound 3: middle estimate off by 2.0-fold (0.30 log units), on the low side; measured number inside the range.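

In this assay, going by these compounds alone, compound 3 gives 1 h, the first value that is a number and not a limit, so the shared core with pyrazin-2-yl on this aromatic carbon, next to the ring oxygen, has a half-life that can be read. Compound 2 gives > 1 h, which is a limit of the assay. Pyrazin-2-yl in place of 4-fluoro-3-methoxyphenyl gives a number no higher from compound 2 to compound 3 (the limit leaves the size open) and the size of this change cannot be read because one end of it is such a limit: the limit of > 1 h in this assay, at which 1 of the 3 values shown sits.

On these data alone, compound 1 differs from compound 3 in more than one place, so what the chain contributes on its own stays open. As far as these compounds go, how a pyridin-2-yl group, with one ring nitrogen, would compare at this position also stays open.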